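From compound 2 to compound 4: a piperazine exchange

The source may hold more compounds than are shown below. What is called first, only, known or untested is meant among the compounds shown, and "the series" means these compounds.

In a functional assay on MV4-11 cells (Homo sapiens) for inhibition, read by luminescence, with a stated time of 3 days (a higher number here means a weaker inhibitor of growth, a lower number a stronger inhibitor of growth), compound 1 (`CC(=O)N1CCN(C(=O)[C@@H]2CC[C@@H](C)N2C(=O)C2=C(C(C)C)N3C(=N[C@@](C)(c4ccc(Cl)cc4)[C@H]3c3ccc(Cl)cc3)S2)CC1`) gives 270 nM, compound 3 (`CC(C)C1=C(C(=O)N2[C@H](C)CC[C@H]2C(=O)N2CCN(C)C(C)(C)C2)SC2=N[C@@](C)(c3ccc(Cl)cc3)[C@@H](c3ccc(Cl)cc3)N21`) gives 280 nM and compound 2 (`CC[C@@H]1CC[C@@H](C(=O)N2CCN(C(C)=O)CC2)N1C(=O)C1=C(C(C)C)N2C(=N[C@@](C)(c3ccc(Cl)cc3)[C@H]2c2ccc(Cl)cc2)S1`) gives 130 nM, the lowest of the three numbers. Compound 4 (`CC[C@@H]1CC[C@@H](C(=O)N2CCN(C)[C@@H](C)C2)N1C(=O)C1=C(C(C)C)N2C(=N[C@@](C)(c3ccc(Cl)cc3)[C@H]2c2ccc(Cl)cc2)S1`) has 3,4-dimethylpiperazin-1-yl in place of 4-acetylpiperazin-1-yl on a carbonyl carbon. Going by the values given here, the closest precedent is another exchange of the group on that carbonyl carbon, a 1.0-fold higher number from compound 1 to compound 3 (0.02 log units; within the scatter). The remaining measured step, a 2.1-fold lower number from compound 1 to compound 2 (0.32 log units; beyond the scatter), is a different change and is already contained in compound 2. The expected step is a 1.1-fold higher number from compound 2 to compound 4 (0.03 log units; within the scatter), none beyond the scatter. Among the compounds with values here, with only one precedent, the range stays wide. For compound 4 the estimated value is 140 nM, with an expected range of 60 nM to 320 nM.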

Compound 4, concentration for 50% growth inhibition: 250 nM
The estimate for compound 4 lay 1.8-fold (0.25 log units) below the measured number, and the stated range covers the measured number.
By their numbers in this assay, from the lowest: compounds 2, 4, 1 and 3 (each within the scatter of the next, the first and the last beyond it).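

Exchanging 4-acetylpiperazin-1-yl for 3,4-dimethylpiperazin-1-yl gives a 1.9-fold higher number from compound 2 to compound 4 (0.28 log units; within the scatter), so this exchange on the carbonyl carbon stays inside the scatter, like a 1.0-fold higher number from compound 1 to compound 3 (0.02 log units; within the scatter). Both compound 3 and compound 4 lack the acetyl group, and neither step goes beyond the scatter, whether it starts from compound 1 or compound 2. Nothing at hand gives a cause for this result.

Still open, on these data alone, is how the opposite configuration at the defined stereocentre of 3,4-dimethylpiperazin-1-yl would read. Also open, as far as these compounds go, is whether a morpholin-4-yl group or a piperazine carrying a carboxylic acid on that carbonyl carbon would stay within the scatter.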